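From 2,4-Dimethoxyphenyl to 3-Chloro-4-fluorophenyl

A few compounds are considered here, and "the series" means these few. Any claim that something is new, unique, unknown or untested is made for them only; others in the source may bear on it.

In a functional assay on B16 cells (Mus musculus) for antiproliferative activity, with a stated time of 72 h (on this read-out lower numbers stand for stronger inhibition and higher numbers for weaker inhibition), compound 1 `OC[C@H]1O[C@@H](n2cnc3c(NCc4ccc(F)cc4)ncnc32)[C@H](O)[C@@H]1O` has the entry "not determined" (no result reported). Compound 2 `COc1ccccc1CNc1ncnc2c1ncn2[C@@H]1O[C@H](CO)[C@@H](O)[C@H]1O` gives > 166000 nM, which is a limit and not a number. Compound 3 `COc1ccc(CNc2ncnc3c2ncn3[C@@H]2O[C@H](CO)[C@@H](O)[C@H]2O)c(OC)c1` stands without a single number, its entry being "not determined" (no result reported). Compound 4 `OC[C@H]1O[C@@H](n2cnc3c(NCc4ccc(F)c(Cl)c4)ncnc32)[C@H](O)[C@@H]1O` remains to be measured. The change 3-chloro-4-fluorophenyl in place of 2,4-dimethoxyphenyl on a saturated chain carbon bound to a nitrogen on an aromatic ring puts 3-chloro-4-fluorophenyl in place of 2,4-dimethoxyphenyl on a saturated chain carbon bound to a nitrogen on an aromatic ring. Among the measured compounds shown here, no measured step guides this change. The only reference available is the limit of > 166000 nM in this assay, at which 1 of the 3 values shown sits. A modest move toward stronger inhibition in this assay is expected, though a result at the limit would be no surprise. For compound 4 the estimated value is 80000 nM, with an expected range of 15000 nM to 250000 nM.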

Compound 4, half-maximal inhibitory concentration: 167000 nM
Estimate against measurement, compound 4: 2.1-fold (0.32 log units) below; the measured number falls inside the stated range.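

No new step can be read between compound 2 and compound 4: the entry for compound 2 is a limit and not a number. The compounds shown leave open how the groups on the saturated chain carbon bound to a nitrogen on an aromatic ring compare in this assay.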